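Replacing thiophen-2-yl with 4-methoxyphenyl in compound 2

This account rests on a few compounds, and the source may have more. Where it says the series, first, only, none or still open, it means among the compounds named here.

Measured in a functional assay on COLO 205 cells (Homo sapiens) for inhibition, read by sulforhodamine B assay, with a stated time of 48 h, tested at 50 uM; a lower number here means less inhibition of growth, a higher number more inhibition of growth at the concentration tested:
compound 1 `COc1cc(/C=C/C(=O)/C=C/c2cccc3ccccc23)ccc1OCc1cn(CCCOc2cc(=O)oc3ccccc23)nn1` gives 64%
compound 2 `COc1cc(/C=C/C(=O)/C=C/c2cccs2)ccc1OCc1cn(CCOc2cc(=O)oc3ccccc23)nn1` gives 66%
compound 3 `COc1cc(/C=C/C(=O)/C=C/c2ccccc2)ccc1OCc1cn(CCCCOc2cc(=O)oc3ccccc23)nn1` gives 31%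

Compound 2 stands level with compound 1 within the scatter, and clearly above compound 3. Compound 4 `COc1ccc(/C=C/C(=O)/C=C/c2ccc(OCc3cn(CCOc4cc(=O)oc5ccccc45)nn3)c(OC)c2)cc1` carries 4-methoxyphenyl in place of thiophen-2-yl on a double-bonded chain carbon bound to a double-bonded chain carbon and is otherwise the same as compound 2. Among the compounds with values here, no two measured compounds differ in one place only, so the data give no direct size for this swap. Compound 1 at 64% and compound 3 at 31% both differ from compound 2 in more than one place, which leaves the expectation wide. The expected step of a number 10 percentage points lower from compound 2 to compound 4 (within the scatter) is a modest fall, about the size of the usual scatter. In this assay the estimate for compound 4 is 56% with an expected range from 36% to 74% on testing.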

Compound 4, percent growth inhibition at one concentration: 68%
For compound 4 the middle estimate is 12 percentage points below the measured one; low and high end bracket the measured number.
By their numbers in this assay, from the lowest: compound 3; then compounds 1, 2 and 4 (each within the scatter of the next).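

Within the data shown here, the step of a number 2 percentage points higher from compound 2 to compound 4 (within the scatter) in this assay is the first comparison here that differs in one place only. It shows that this position on a double-bonded chain carbon bound to a double-bonded chain carbon accepts 4-methoxyphenyl, with 8 heavy atoms, as well as thiophen-2-yl, with 5, and growth inhibition stays level within the scatter. Sulfur in a five-membered aromatic ring is therefore not needed at this place in this pair.

From the compounds shown here alone, whether a group such as an amine or a carboxylic acid would also hold the number at this place remains open. Nothing measured here explains why the two groups match.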